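The source may hold more compounds than are shown below. What is called first, only, known or untested is meant among the compounds shown, and "the series" means these compounds.

In a functional assay on HCT-116 cells (Homo sapiens) for antiproliferative activity, read by sulforhodamine B assay, with a stated time of 4 days (a lower number here means a stronger inhibitor of growth, a higher number a weaker inhibitor of growth), compound 1 (`COc1cc(Cl)c(-c2nc(SCC(=O)NC3CC3)nc3[nH]cc(C#N)c23)cc1OC`) gives 60 nM and compound 2 (`COc1cc(Cl)c(-c2nc(SCC(=O)NC(C)(C)C)nc3[nH]cc(C#N)c23)cc1O`) gives 117 nM. These two numbers lie within the usual scatter of repeated measurements, so compound 2 cannot be ranked against compound 1. The two also differ in more than one place, so no single change has yet been measured on its own. Compound 3 (`COc1cc(Cl)c(-c2nc(SCC(=O)NC(C)(C)C)nc3[nH]cc(C#N)c23)cc1OC`) departs from compound 2 in one place only: methyl in place of hydrogen on an oxygen on an aromatic ring, which is methyl in place of hydrogen on an oxygen on an aromatic ring, or hydroxy to methoxy. For the measured compounds named here, compound 1, which has methoxy there as well, gives 60 nM, and this is the only guide available. The expected step of a 1.6-fold lower number from compound 2 to compound 3 (0.19 log units; within the scatter) in this assay is small, pointing towards a lower number and probably not beyond the scatter. For compound 3 the estimated value is 75 nM, with an expected range of 28 nM to 200 nM.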

Compound 3, concentration for 50% growth inhibition: 50 nM
Compound 3: the middle estimate sits 1.5-fold (0.18 log units) above what was measured, and the stated range covers the measured number.
By their numbers in this assay, from the lowest: compounds 3, 1 and 2 (each within the scatter of the next, the first and the last beyond it).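

In this assay, changing hydroxy to methoxy on the aromatic ring gives a 2.3-fold lower number from compound 2 to compound 3 (0.37 log units; beyond the scatter), a single change seen on its own, so adding this one methyl on the oxygen has a modest but real effect on the number. The other single change, tert-butyl in place of cyclopropyl on an amide-type nitrogen, gives a 1.2-fold lower number from compound 1 to compound 3 (0.08 log units; within the scatter), so with methoxy on the ring these two amide groups cannot be told apart. No measurement at hand explains the effect of the methyl.

From the compounds shown here alone, whether a longer chain on that oxygen, such as ethoxy or propoxy, would go further or lose the effect remains open. Going by these compounds, it is also open whether hydroxy to methoxy would give a similar step with cyclopropyl on the amide.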